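The compounds below may be only part of what the source reports. "The series", "measured", "known", "first", "only" and "open" are said of these compounds alone.

The measured compounds:
Compound 1, `COc1cc(N)c(Cl)cc1NC(=O)C1CCN(Cc2cccc(C#N)c2)CC1`: in a functional assay on the whole organism for antagonist activity, with Mus musculus as the target (a lower number here means that less compound is needed, a higher number that more compound is needed for the effect), compound 1 gives only a limit of the assay, > 4 mg/kg.
Compound 2, `CCCCCN1CCC(C(=O)Nc2cc(Cl)c(N)cc2OC)CC1`: in this assay compound 2 gives only a limit of the assay, > 10 mg/kg.
Compound 3, `CCC(CC)CN1CCC(C(=O)Nc2cc(Cl)c(N)cc2OC)CC1`: in this assay compound 3 gives only a limit of the assay, > 10 mg/kg.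

Compound 3 therefore stands at a limit in this assay, and the two further values shown are limits as well (the limit of > 10 mg/kg in this assay, at which 2 of the 3 values shown sit, (the limit of > 4 mg/kg in this assay, at which 1 of the 3 values shown sits)). Compound 4, `COc1cc(N)c(Cl)cc1NC(=O)C1CCN(Cc2ccc(O)cc2)CC1`, differs from compound 3 in one place: 4-hydroxyphenyl in place of pentan-3-yl on a saturated chain carbon bound to an amine nitrogen in a ring. The step from compound 1 to compound 3 exchanges an aromatic ring for pentan-3-yl at the same place, and the two other steps touch the same position, but none of them can be sized: a step that the two limits leave unreadable from compound 1 to compound 3, a step that the two limits leave unreadable from compound 1 to compound 2, a step that the two limits leave unreadable from compound 2 to compound 3. With three limits and no readable step, the account can expect no step beyond the scatter in either direction, and the estimate for compound 4 is 10 mg/kg, ranging from 2 mg/kg to 40 mg/kg. The step this estimate implies is expected to be a number no higher from compound 3 to compound 4 (the limit leaves the size open), with a fair chance that compound 4 again returns only a limit.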

Compound 4, dose for half-maximal effect: > 8 mg/kg
Compound 4: a limit, no number; the forecaster's own chance of this, stated with the estimate: 65%; the middle value does not contradict the limit.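

In this assay compound 4 gives only a limit, > 8 mg/kg. Its steps from compound 1, compound 2 and compound 3 cannot be read, as all four values are limits. The compounds shown leave open how much of any of them gives the effect, and whether exchanging these groups changes it at all.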